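This account rests on a few compounds, and the source may have more. Where it says the series, first, only, none or still open, it means among the compounds named here.

In a functional assay on SW480 cells (Homo sapiens) for cytotoxicity, read by MTT assay, with a stated time of 48 h (a lower number here means a stronger inhibitor, a higher number a weaker inhibitor), compound 1 `Cc1cccc(Cn2cc(COc3ccc4c(=O)ccoc4c3)nn2)c1` gives 11700 nM, and compound 2 `O=c1ccoc2cc(OCc3cn(Cc4ccccc4Cl)nn3)ccc12` gives 23500 nM. Compound 3 `C#CCOc1ccc2c(=O)ccoc2c1` gives only a limit of the assay, > 100000 nM; this is the limit of > 100000 nM in this assay, at which 1 of the 3 values shown sits. The one measured step, a 2.0-fold higher number from compound 1 to compound 2 (0.30 log units; within the scatter), stays within the scatter, so compounds 1 and 2 cannot be told apart, although compound 2 holds the higher of the two numbers shown. Compound 4 `N#Cc1cccc(Cn2cc(COc3ccc4c(=O)ccoc4c3)nn2)c1` has not yet been measured; it differs from compound 2 by 3-cyanophenyl in place of 2-chlorophenyl on a saturated chain carbon bound to an aromatic nitrogen. Among the measured compounds shown here, the only step that bears on this, a 2.0-fold higher number from compound 1 to compound 2 (0.30 log units; within the scatter), also swaps one substituted phenyl for another at the same place, so no change beyond the scatter is expected here either. Compound 4 is therefore estimated at 16000 nM, with a range from 6000 nM to 45000 nM. That estimate means a step of a 1.5-fold lower number from compound 2 to compound 4 (0.17 log units; within the scatter).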

Compound 4, half-maximal inhibitory concentration: > 100000 nM
Compound 4 gave a limit, no number; the forecaster's own chance of this, stated with the estimate: 10%; middle value at least 6.2-fold (0.79 log units) away from the limit.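

At this place, on a saturated chain carbon bound to an aromatic nitrogen, the choice of substituted phenyl can matter in this assay: the change to 3-cyanophenyl gives an at least 4.2-fold higher number from compound 2 to compound 4 (0.62 log units; beyond the scatter), while the earlier swap stayed within the scatter. Cyano in place of methyl on an aromatic carbon, a single change, gives an at least 8.5-fold higher number from compound 1 to compound 4 (0.93 log units; beyond the scatter). The value of compound 4 is a limit and not a number, so both steps give only a minimum size: the limit of > 100000 nM in this assay, at which 2 of the 4 values shown sit.

The compounds shown leave open whether an amine or a carboxylic acid in place of the nitrile would give a measurable number. They also leave open how far the nitrile itself, rather than any other group there, accounts for this step.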